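Hydrazone aryl variation on a shared benzothiazolyl-benzoyl core

The source may report more compounds than this note shows. Statements on the series, on what has been measured and on what is new or still open speak of the compounds shown alone.

Measured in an assay on isolated protein for inhibition of Maltase-glucoamylase (Homo sapiens), with a stated time of 15 min; on this read-out lower numbers stand for stronger inhibition and higher numbers for weaker inhibition:
- compound 1 `COc1ccc(O)c(/C=N/NC(=O)c2ccc(-c3nc4ccccc4s3)cc2)c1` gives 6500 nM
- compound 2 `O=C(N/N=C/c1ccc(O)c(O)c1)c1ccc(-c2nc3ccccc3s2)cc1` gives 15100 nM
- compound 3 `O=C(N/N=C/c1ccccc1)c1ccc(-c2nc3ccccc3s2)cc1` gives 8050 nM

Compound 2 holds the highest of the three numbers in this assay. For the measured compounds named here, its gap to compound 3 is a 1.9-fold lower number from compound 2 to compound 3 (0.27 log units; within the scatter), so the two are not separated; the only step beyond the scatter is a 2.3-fold higher number from compound 1 to compound 2 (0.37 log units; beyond the scatter). Compound 1 and compound 3 sit together, a 1.2-fold higher number from compound 1 to compound 3 (0.09 log units; within the scatter).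

Compound 4 `O=C(N/N=C/c1cccc(O)c1)c1ccc(-c2nc3ccccc3s2)cc1` is the next member. It differs from compound 2 in one place: hydrogen in place of hydroxy on an aromatic carbon. Going by the values given here, the change moves from the 3,4-dihydroxyphenyl of compound 2 partway toward the plain phenyl of compound 3, so the step that bears on it most directly is the one from compound 2 to compound 3, which stayed within the scatter. The step from compound 1 to compound 2 shows that changing the hydroxy pattern on this ring can shift the number modestly, but nothing here singles out the hydroxy that leaves. Among the compounds with values here, the expectation for compound 4 is therefore a number between those of compound 2 and compound 3, with no step clearly beyond the scatter.

In this assay compound 4 is estimated at 10000 nM, with a range of 5000 nM to 20000 nM. This estimate means an expected step of a 1.5-fold lower number from compound 2 to compound 4 (0.18 log units; within the scatter).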

Compound 4, half-maximal inhibitory concentration: 9210 nM
Compound 4: the middle estimate sits 1.1-fold (0.04 log units) above what was measured, and the stated range covers the measured number.
By their numbers in this assay, from the lowest: compounds 1, 3, 4 and 2 (each within the scatter of the next, the first and the last beyond it).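

In this assay, removing the hydroxy para to a large group, which turns 3,4-dihydroxyphenyl into 3-hydroxyphenyl, gives a 1.6-fold lower number from compound 2 to compound 4 (0.21 log units; within the scatter) and so resolves no effect of that single hydroxy, while placing the remaining hydroxy on the plain phenyl gives a 1.1-fold higher number from compound 3 to compound 4 (0.06 log units; within the scatter) and likewise separates nothing. For the compounds shown here, replacing 2-hydroxy-5-methoxyphenyl with 3-hydroxyphenyl gives a 1.4-fold higher number from compound 1 to compound 4 (0.15 log units; within the scatter) as well, so compound 4 is separated from none of the other three compounds, and the only separated pair remains compound 1 and compound 2, a gap that no single step through compound 4 reproduces. No measured information on the compounds bears on why these numbers fall as they do.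

Still open, going by these compounds, is how the separation between compound 1 and compound 2 divides among the ring changes that distinguish them, since those two rings differ in more than one substituent and no intermediate here isolates the methoxy. Also open, on these data alone, is whether a different group on this ring, such as an amine or a carboxylic acid, would give a step beyond the scatter from the plain phenyl of compound 3.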